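Trading a methoxyethyl chain for a methoxycyclohexyl ring

This account rests on a few compounds, and the source may have more. Where it says the series, first, only, none or still open, it means among the compounds named here.

In an ADME assay on the whole organism with Rattus norvegicus as the target, at a dose of 2 mg/kg by the intravenous route (a lower number here means that the compound disappears faster, a higher number that the compound lasts longer), compound 1 `Cc1nc(-c2nc[nH]n2)ccc1-c1cnc2c(n1)N(C(C)C)C(=O)CN2` gives 3.9 h and compound 2 `COCCN1C(=O)CNc2ncc(-c3ccc(-c4nc[nH]n4)nc3C)nc21` gives 2.2 h on the same core. These two numbers are all that is known so far, and they lie within the scatter of each other, so compound 2 stands level with compound 1.

Compound 3 `CO[C@H]1CC[C@H](N2C(=O)CNc3ncc(-c4ccc(-c5nc[nH]n5)nc4C)nc32)CC1` differs from compound 2 on an amide-type nitrogen in a ring, with 4-methoxycyclohexyl in place of 2-methoxyethyl. The change is counted as 4-methoxycyclohexyl in place of 2-methoxyethyl on an amide-type nitrogen in a ring and brings in one six-membered non-aromatic ring of carbon only.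

Within the data shown here, one measured step bears on this place. It is a 1.8-fold lower number from compound 1 to compound 2 (0.25 log units; within the scatter) with 2-methoxyethyl in place of isopropyl, and it stayed within the scatter. Among the measured compounds shown here, no compound with a ring at this nitrogen has been measured, so that step offers a size but no firm direction. In this assay the expected change is therefore small, an estimated 1.3-fold higher number from compound 2 to compound 3 (0.10 log units; within the scatter) and no step beyond the scatter. For compound 3 the estimate is 2.8 h with an expected range from 1.4 h to 5.5 h in mean residence time.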

Compound 3, mean residence time: 6.5 h
For compound 3 the middle estimate is 2.3-fold (0.37 log units) below the measured one; measured number above the stated range.
By their numbers in this assay, from the lowest: compounds 2, 1 and 3 (each within the scatter of the next, the first and the last beyond it).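

In this assay, among these compounds, a carbon ring on the amide-type nitrogen gives the first step at this position that lies beyond the scatter, a 3.0-fold higher number from compound 2 to compound 3 (0.47 log units; beyond the scatter), whereas the earlier step between two open-chain groups stayed within it. Against isopropyl the same group gives a 1.7-fold higher number from compound 1 to compound 3 (0.22 log units; within the scatter), so 4-methoxycyclohexyl stands apart from 2-methoxyethyl but not from isopropyl, and the position responds to this change only in that one comparison. Nothing available accounts for the step, which therefore remains an observation without an explanation.

The change brings in the six-membered ring and the 2 defined stereocentres together and moves the methoxy group onto that ring, so the compounds shown cannot say which of these features goes with the longer residence time. A plain cyclohexyl group would separate the ring from its methoxy group, while the other stereoisomer of 4-methoxycyclohexyl or a 4-hydroxycyclohexyl group would show whether the arrangement and the identity of the oxygen substituent matter at this nitrogen.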